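Cytotoxicity in the hydrazone series: methyl for bromo

The compounds below may be only part of what the source reports. "The series", "measured", "known", "first", "only" and "open" are said of these compounds alone.

Measured so far, in an ADME assay on THP-1 cells (Homo sapiens) for cytotoxicity, read by MTT assay, tested at 50 ug/mL; a lower number here means less inhibition, a higher number more inhibition at the concentration tested (going by the name of the read-out):
compound 1, `C(=N/Nc1nc(-c2ccccc2)cs1)\c1ccc(-n2cncn2)cc1`, gives 28.4%
compound 2, `Brc1ccc(-c2csc(N/N=C/c3ccc(-n4cncn4)cc3)n2)cc1`, gives 32.6%

Going by the values given here, only one step between measured compounds is available: bromo in place of hydrogen on an aromatic carbon, which gave a number 4.2 percentage points higher from compound 1 to compound 2 (within the scatter), a change within the scatter. Compound 2 therefore stands with compound 1 inside the scatter; the two numbers shown cannot be told apart, and neither compound can be called the more inhibiting one.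

Compound 3, `Cc1ccc(-c2csc(N/N=C/c3ccc(-n4cncn4)cc3)n2)cc1`, carries the change (methyl in place of bromo on an aromatic carbon). Among the compounds with values here, no measured step exchanges methyl for anything; the bromo-for-hydrogen step at the same carbon, a number 4.2 percentage points higher from compound 1 to compound 2 (within the scatter), is the only guide, and it stayed within the scatter. Because a number 4.2 percentage points higher from compound 1 to compound 2 (within the scatter) was small, the expectation for compound 3 is a step of no real size in either direction: a number 2.6 percentage points lower from compound 2 to compound 3 (within the scatter) is expected to lie within the scatter. Compound 3 is therefore estimated at 30%, with a range from 18% to 42%.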

Compound 3, a percentage reported as inhibition, at one concentration (the size of the read-out at that concentration, not a potency): 13.6%
The estimate for compound 3 lay 16.4 percentage points above the measured number; measured number below the stated range.
By their numbers in this assay, from the lowest: compound 3; then compounds 1 and 2 (each within the scatter of the next).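

In this assay, this aromatic carbon, para to a large group, proves able to shift the number beyond the scatter: the change from 4-bromophenyl to 4-methylphenyl gives a number 19 percentage points lower from compound 2 to compound 3 (beyond the scatter), and methyl in place of hydrogen at the same carbon gives a number 14.8 percentage points lower from compound 1 to compound 3 (beyond the scatter). Compound 1 and compound 2 cannot be told apart, so the two steps agree in direction and the series at this carbon reads as hydrogen and bromo together, with methyl lower than both; the earlier step alone gave no sign that this carbon could matter. Bromo and methyl carry the same count of one heavy atom and no hydrogen-bond donors or acceptors, so these counts do not separate them, and no other information on the compounds speaks to the origin of this gap.

Still open, from the compounds shown here alone, is whether the lower number is particular to methyl or extends to an ethyl group or a longer chain, and whether a methoxy group or an amine at this carbon would read with methyl or with hydrogen and bromo. Also open, going by these compounds, is whether the methyl step keeps its size when another part of the shared core is changed.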